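Dichlorophenyl for tert-butylphenyl in a sulfonamide series

This account rests on a few compounds, and the source may have more. Where it says the series, first, only, none or still open, it means among the compounds named here.

Measured compounds:
Compound 1, `CC(C)(C)c1ccc(CNCCCNS(=O)(=O)c2cc(C(F)(F)F)cc(C(F)(F)F)c2)cc1`, gives 2300 nM in a functional assay on HPAC cells (Homo sapiens) for inhibition, read by MTT assay, with a stated time of 72 h; on this read-out higher numbers stand for weaker inhibition of growth and lower numbers for stronger inhibition of growth.
Compound 2, `CN(CCCNS(=O)(=O)c1cc(C(F)(F)F)cc(C(F)(F)F)c1)Cc1ccccc1`, gives 30000 nM in this assay.
Compound 3, `COc1ccccc1CNCCCNS(=O)(=O)c1cc(C(F)(F)F)cc(C(F)(F)F)c1`, gives 2400 nM in this assay.

Compound 1 gives the lowest of the three numbers in this assay, but compound 3 sits within the scatter of it, so the two cannot be ordered; only compound 2 stands clearly apart, beyond the scatter.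

Compound 4, `O=S(=O)(NCCCNCc1ccc(Cl)c(Cl)c1)c1cc(C(F)(F)F)cc(C(F)(F)F)c1`, has not yet been measured. It differs from compound 1 in one place: 3,4-dichlorophenyl in place of 4-(tert-butyl)phenyl on a saturated chain carbon bound to an amine nitrogen.

Within the data shown here, one measured step bears on this change. The step of a 1.0-fold higher number from compound 1 to compound 3 (0.02 log units; within the scatter) also swaps the aryl group on the saturated chain carbon bound to the amine nitrogen, and it left the number essentially unmoved. The step of a 13-fold lower number from compound 2 to compound 3 (1.10 log units; beyond the scatter) concerns the amine nitrogen itself rather than the aryl group, so it does not speak to the present change. Among the measured compounds shown here, with only a single relevant step, and that one within the scatter, no shift beyond the scatter is expected for compound 4 in this assay.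

Compound 4 is therefore expected to give about 2000 nM in this assay, with a range from 700 nM to 6000 nM, a step of a 1.2-fold lower number from compound 1 to compound 4 (0.06 log units; within the scatter) that is estimated to stay within the scatter.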

Compound 4, concentration for 50% growth inhibition: 2500 nM
Beside the measured number, compound 4's estimate is 1.3-fold (0.10 log units) below it; low and high end bracket the measured number.
By their numbers in this assay, from the lowest: compounds 1, 3 and 4 (each within the scatter of the next); then compound 2.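

In this assay, the change to 3,4-dichlorophenyl gives a 1.1-fold higher number from compound 1 to compound 4 (0.04 log units; within the scatter), and the comparison with the 2-methoxyphenyl analogue gives a 1.0-fold higher number from compound 3 to compound 4 (0.02 log units; within the scatter), so this position on the saturated chain carbon bound to an amine nitrogen has now taken three differently substituted aryl groups with no step beyond the scatter, including one with chlorine atoms and no carbon substituent on the ring. The large gap to the tertiary amine also recurs with this second aryl group, as a 12-fold lower number from compound 2 to compound 4 (1.08 log units; beyond the scatter), so the separation of compound 2 from the others no longer rests on a single comparison. No measured evidence explains why these aryl changes leave the number within the scatter or why compound 2 stands apart.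

The compounds shown leave open whether the gap belongs to the methyl on the amine nitrogen or to the unsubstituted phenyl ring of compound 2, since a plain benzylamino group is not among them. They also say nothing about whether this tolerance extends to a pyridine ring or a carboxylic acid on the ring, or whether it would hold with a longer chain between the two nitrogens.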